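Compound 4: nitro in place of methoxy

The source may report more compounds than this note shows. Statements on the series, on what has been measured and on what is new or still open speak of the compounds shown alone.

In a functional assay on Bel-7402 cells (Homo sapiens) for inhibition, read by MTT assay, with a stated time of 24 h, tested at 1 ug/mL (on this read-out lower numbers stand for less inhibition of growth and higher numbers for more inhibition of growth at the one concentration tested), compound 1 (`O=C(CCCCC(S)CCS)Nc1ccccc1`) gives 1.32% as its reading. Compound 2 (`O=C(CCCCC(S)CCS)Nc1ccc(F)cc1`) has "not active" (no number reported) as its entry with no number given. Compound 3 (`COc1ccc(NC(=O)CCCCC(S)CCS)cc1`) gives 3.96% and so stands within the scatter of compound 1. Compound 4 (`O=C(CCCCC(S)CCS)Nc1ccc([N+](=O)[O-])cc1`) carries nitro in place of methoxy on an aromatic carbon, para to a large group (nitro in place of methoxy on an aromatic carbon). Among the measured compounds shown here, the one measured step bearing on this change is methoxy in place of hydrogen (a number 2.6 percentage points higher from compound 1 to compound 3 (within the scatter)) and it is small. No step beyond the scatter is therefore expected in this assay for this exchange. What is expected is a number 1 percentage points lower from compound 3 to compound 4 (within the scatter) and no more. For compound 4 the estimate is 3% with an expected range from 0% to 12% as a working figure.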

Compound 4, percent growth inhibition at one concentration: 1.73%
Compound 4: the middle estimate sits 1.3 percentage points above what was measured, within the range that was stated.
By their numbers in this assay, from the lowest: compounds 1, 4 and 3 (each within the scatter of the next).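

Nitro in place of methoxy gives a number 2.2 percentage points lower from compound 3 to compound 4 (within the scatter) in this assay and nitro in place of hydrogen gives a number 0.4 percentage points higher from compound 1 to compound 4 (within the scatter) on the same read-out. On an aromatic carbon para to a large group, a third substituent therefore joins hydrogen and methoxy without being told apart from them at the one concentration tested. No measured evidence bears on this result.

As far as these compounds go, whether an amine or a carboxylic acid at this place would give a step beyond the scatter stays open. So does the effect of a longer chain on the shared core.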